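This account rests on a few compounds, and the source may have more. Where it says the series, first, only, none or still open, it means among the compounds named here.

Measured compounds in a functional assay on SiHa cells (Homo sapiens) for cytotoxicity, read by MTT assay, with a stated time of 48 h; on this read-out lower numbers stand for stronger inhibition and higher numbers for weaker inhibition:
- compound 1 `CCCCCCCCCCCCNC(=O)[C@@H](NC(=O)c1cccs1)[C@@H](C)O` gives 23900 nM
- compound 2 `CCCCCCCCCCCCNC(=O)[C@@H](NC(=O)c1cc2ccccc2[nH]1)[C@@H](C)O` gives 21300 nM
- compound 3 `CCCCCCCCCCCCNC(=O)[C@@H](NC(=O)/C=C/c1ccccc1)[C@@H](C)O` is reported only as a limit, > 200000 nM

Compound 1 holds the higher of the two numbers in this assay, with compound 2 nearest; that gap, a 1.1-fold lower number from compound 1 to compound 2 (0.05 log units; within the scatter), is within the scatter, so the two are not ordered. The value of compound 3 is a limit of the assay (the limit of > 200000 nM in this assay, at which 1 of the 3 values shown sits). The two steps leading to it, an at least 8.3-fold higher number from compound 1 to compound 3 (0.92 log units; beyond the scatter) and an at least 9.3-fold higher number from compound 2 to compound 3 (0.97 log units; beyond the scatter), both change the group on the carbonyl carbon and leave the saturated chain untouched.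

Compound 4 `CCCCCCCCCCCCCCNC(=O)[C@@H](NC(=O)c1cccs1)[C@@H](C)O` differs from compound 1 by ethyl in place of hydrogen on a saturated chain carbon, ten or more bonds along the chain from an amide-type nitrogen. Going by the values given here, no measured step varies this chain, so none bears directly on the change; every step in hand concerns the group on the carbonyl carbon. In this assay the step from compound 1 to compound 4 is therefore expected to be none beyond the scatter, no change at the digits printed from compound 1 to compound 4 (within the scatter). Compound 4 is estimated at 23900 nM, with a range of 8000 nM to 70000 nM.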

Compound 4, half-maximal inhibitory concentration: 63000 nM
For compound 4 the middle estimate is 2.6-fold (0.42 log units) below the measured one; low and high end bracket the measured number.
By their numbers in this assay, from the lowest: compounds 2 and 1 (each within the scatter of the next); then compound 4. At a limit, above all of these: compound 3.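

In this assay the saturated chain turns out to be a position that responds: ethyl in place of hydrogen on a saturated chain carbon, ten or more bonds along the chain from an amide-type nitrogen, gives a 2.6-fold higher number from compound 1 to compound 4 (0.42 log units; beyond the scatter) with the thiophen-2-yl group held fixed, a modest step beyond the scatter. Going by these compounds alone, the earlier steps varied only the group on the carbonyl carbon, so this single pair is the first reading on the chain, and here the longer chain carries the higher number, meaning weaker inhibition. Nothing measured in hand speaks to the origin of this step.

On these data alone, whether the step holds with 1H-indol-2-yl or 2-phenylethenyl on the carbonyl carbon stays open. A shorter chain such as octyl, or a chain carrying an amine or a carboxylic acid, would test whether the number follows chain length at all.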